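A Fluoro Step on Compound 1

The source may hold more compounds than are shown below. What is called first, only, known or untested is meant among the compounds shown, and "the series" means these compounds.

In an ADME assay on the whole organism (plasma) for pharmacokinetics, with Rattus norvegicus as the target, with a stated time of 24 h, at a dose of 10 mg/kg by the oral route (on this read-out higher numbers stand for higher exposure at the dose given and lower numbers for lower exposure), compound 1 `CCc1ccc2c(c1)c(-c1ccc[nH]c1=O)c(C(=O)NS(=O)(=O)C1CC1)n2Cc1cc(F)ccc1F` gives 6140 ng.h/mL and compound 2 `CC(C)(C)c1ccc2c(c1)c(-c1ccc[nH]c1=O)c(C(=O)NS(=O)(=O)C1CC1)n2Cc1cc(F)ccc1F` gives 4320 ng.h/mL, so the two lie within the scatter of each other. Compound 3 `CCc1cc2c(-c3ccc[nH]c3=O)c(C(=O)NS(=O)(=O)C3CC3)n(Cc3cc(F)ccc3F)c2cc1F` differs from compound 1 by fluoro in place of hydrogen on an aromatic carbon. Going by the values given here, the only measured step, a 1.4-fold lower number from compound 1 to compound 2 (0.15 log units; within the scatter), is a change at another carbon and bears on this one only loosely. It gives no reason to expect a shift beyond the scatter. The expected step is a 1.1-fold lower number from compound 1 to compound 3 (0.05 log units; within the scatter). Compound 3 is estimated at 5500 ng.h/mL, within an expected range of 2500 ng.h/mL to 12000 ng.h/mL.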

Compound 3, area under the concentration-time curve: 3390 ng.h/mL
Compound 3: middle estimate off by 1.6-fold (0.21 log units), on the high side; low and high end bracket the measured number.
By their numbers in this assay, from the lowest: compounds 3, 2 and 1 (each within the scatter of the next).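

In this assay, fluoro on the carbon ortho to the ethyl group gives a 1.8-fold lower number from compound 1 to compound 3 (0.26 log units; within the scatter), so at this carbon the added atom leaves the two compounds within the scatter of each other. Going by these compounds alone, the earlier pair spoke only to the alkyl group at another carbon, whereas this is the first reading at this position. No measurement on hand accounts for the number. Going by these compounds, whether chloro, methoxy or an amine at this carbon would also stay within the scatter remains open, as does the effect of fluoro alongside tert-butyl in place of ethyl.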